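Ester in place of acetamide on the saturated ring

The source may hold more compounds than are shown below. What is called first, only, known or untested is meant among the compounds shown, and "the series" means these compounds.

Compound 1 `CC(=O)NC1CCC(CN2CCN(c3cc(=O)c4cc(C(F)(F)F)cc([N+](=O)[O-])c4s3)CC2)CC1` stands at the edge of an ADME assay on cells (Hepatocyte, Homo sapiens) for metabolic stability; on this read-out lower numbers stand for a shorter-lived compound and higher numbers for a longer-lived compound: in it compound 1 gives > 1.55 h, a limit of the assay rather than a number (the limit of > 1.55 h in this assay, at which 1 of the 2 values shown sits). Compound 2 `COc1ccc(C(=O)OC2CCC(CN3CCN(c4cc(=O)c5cc(C(F)(F)F)cc([N+](=O)[O-])c5s4)CC3)CC2)cc1` in this assay gives 0.165 h; the step of an at least 9.3-fold lower number from compound 1 to compound 2 (0.97 log units; beyond the scatter) came with ((4-methoxyphenyl)carbonyl)oxy in place of acetamido on a saturated ring carbon. Compound 3 `O=C(OC1CCC(CN2CCN(c3cc(=O)c4cc(C(F)(F)F)cc([N+](=O)[O-])c4s3)CC2)CC1)c1ccccc1` carries a closely related change, (benzoyloxy in place of acetamido on a saturated ring carbon). That measured step is the only one that bears here, so a drop of similar size is expected, an at least 7.7-fold lower number from compound 1 to compound 3 (0.88 log units; beyond the scatter). In this assay compound 3 is estimated at 0.2 h, between 0.08 h and 0.6 h.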

Compound 3, half-life: 0.603 h
Estimate against measurement, compound 3: 3.0-fold (0.48 log units) below; the whole stated range lies below it.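

In this assay the benzoyloxy group also gives a lower number than acetamido, an at least 2.5-fold lower number from compound 1 to compound 3 (0.41 log units; beyond the scatter), so the drop does not depend on the methoxy group of compound 2. The aromatic ring of the ester is also sensitive to change: hydrogen in place of methoxy on an aromatic carbon gives a 3.7-fold higher number from compound 2 to compound 3 (0.56 log units; beyond the scatter). Compound 1 stands at a limit of the assay, so the true size of its steps stays unknown: the limit of > 1.55 h in this assay, at which 1 of the 3 values shown sits.

Still open, going by these compounds, is whether fluoro or nitrile in place of methoxy reads closer to hydrogen or to methoxy. Also open, on these data alone, is whether an amine or a carbamate on the saturated ring carbon behaves more like acetamido or benzoyloxy.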